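Swapping a pyrrole-tetrazole for a thiophene-tetrazole

The source may report more compounds than this note shows. Statements on the series, on what has been measured and on what is new or still open speak of the compounds shown alone.

Measured so far:
compound 1 `Cn1ncnc1-c1ccccc1-c1ccc(CN2C(=O)[C@H](NC(=O)CC(C)(C)N)CCc3ccccc32)cc1`, 265 nM
compound 2 `CC(C)(N)CC(=O)N[C@@H]1CCc2ccccc2N(Cc2ccc(-n3cccc3-c3nn[nH]n3)cc2)C1=O`, 275 nM

In a functional assay (Pituitary gland cell) with Rattus norvegicus as the target (on this read-out higher numbers stand for an effect only at larger amounts of compound and lower numbers for an effect already at smaller amounts), compound 2 stands highest of the two numbers, but its nearest neighbour is compound 1, and the gap between them lies within the scatter. Within the data shown here, the only measured step, a 1.0-fold higher number from compound 1 to compound 2 (0.02 log units; within the scatter), exchanged one aromatic group carrying a small heteroaromatic ring for another at the same aromatic carbon without a change beyond the scatter.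

Compound 3 `CC(C)(N)CC(=O)N[C@@H]1CCc2ccccc2N(Cc2ccc(-c3cscc3-c3nn[nH]n3)cc2)C1=O` is not yet measured. It differs from compound 2 in one place: 4-(2H-tetrazol-5-yl)thiophen-3-yl in place of 2-(2H-tetrazol-5-yl)-1H-pyrrol-1-yl on an aromatic carbon. The change again replaces one five-membered aromatic ring carrying the tetrazole with another, at the same aromatic carbon. Since the comparable exchange seen in a 1.0-fold higher number from compound 1 to compound 2 (0.02 log units; within the scatter) left the number within the scatter, no step beyond the scatter is expected for compound 3 either, so a 1.0-fold higher number from compound 2 to compound 3 (0.01 log units; within the scatter) is estimated to be small. Compound 3 is therefore expected to give about 280 nM in this assay, with a likely range from 100 nM to 800 nM.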

Compound 3, half-maximal effective concentration: 150 nM
For compound 3 the middle estimate is 1.9-fold (0.27 log units) above the measured one; the measured number falls inside the stated range.
By their numbers in this assay, from the lowest: compounds 3, 1 and 2 (each within the scatter of the next).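

In this assay, a 1.8-fold lower number from compound 2 to compound 3 (0.26 log units; within the scatter) and a 1.8-fold lower number from compound 1 to compound 3 (0.25 log units; within the scatter), and both steps lie within the scatter. The new information is that a third group, 4-(2H-tetrazol-5-yl)thiophen-3-yl, with sulfur in its five-membered ring, also leaves the number within the scatter at this aromatic carbon, which sits para to a large group, so all three groups shown here read alike in this assay. No measured evidence bears on this result.

The compounds shown leave open whether the tetrazole ring matters at all, as a carboxylic acid in its place would test. They also leave open what a plain phenyl ring, with no second ring on it, would give at this position.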